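Replacing Pyridin-3-yl with Benzothiophen-2-yl in Compound 3

The compounds below may be only part of what the source reports. "The series", "measured", "known", "first", "only" and "open" are said of these compounds alone.

Compound 3 `Cc1cc(-c2cccnc2)nnc1N1CCN(c2ncccn2)CC1` gives in a functional assay on BV-2 cells (Mus musculus) for inhibition, read by ELISA, with a stated time of 16 h (on this read-out higher numbers stand for weaker inhibition and lower numbers for stronger inhibition), only a limit, > 100000 nM, which is the limit of > 100000 nM in this assay, at which 1 of the 3 values shown sits. Compound 1 `Cc1ccc(-c2cc(C)c(N3CCN(c4ncccn4)CC3)nn2)cc1` gives 17200 nM in this assay, and compound 2 `COc1ccc(-c2cc(C)c(N3CCN(c4ncccn4)CC3)nn2)cc1` gives 5200 nM. The measured steps of an at least 5.8-fold higher number from compound 1 to compound 3 (0.76 log units; beyond the scatter) and an at least 19-fold higher number from compound 2 to compound 3 (1.28 log units; beyond the scatter) both run in one direction: the number rose once pyridin-3-yl entered in place of a substituted phenyl. Compound 4 `Cc1cc(-c2cc3ccccc3s2)nnc1N1CCN(c2ncccn2)CC1` differs from compound 3 by 1-benzothiophen-2-yl in place of pyridin-3-yl on an aromatic carbon. Since the measured steps of an at least 5.8-fold higher number from compound 1 to compound 3 (0.76 log units; beyond the scatter) and an at least 19-fold higher number from compound 2 to compound 3 (1.28 log units; beyond the scatter) went upward when a carbocyclic aromatic group left, a drop of at least modest size is expected when a larger bicyclic aromatic group enters. Compound 4 is therefore expected to give about 8000 nM in this assay, between 1500 nM and 60000 nM. That estimate corresponds to a step of an at least 12-fold lower number from compound 3 to compound 4 (1.09 log units; beyond the scatter).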

Compound 4, half-maximal inhibitory concentration: 24900 nM
The estimate for compound 4 lay 3.1-fold (0.49 log units) below the measured number, and the stated range covers the measured number.
By their numbers in this assay, from the lowest: compound 2; then compounds 1 and 4 (each within the scatter of the next). At a limit, above all of these: compound 3.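

In this assay the change to 1-benzothiophen-2-yl gives an at least 4.0-fold lower number from compound 3 to compound 4 (0.60 log units; beyond the scatter) and so brings a measured number back at this position. With a 1.4-fold higher number from compound 1 to compound 4 (0.16 log units; within the scatter) the bicyclic group is not separated from 4-methylphenyl, while a 4.8-fold higher number from compound 2 to compound 4 (0.68 log units; beyond the scatter) leaves it short of 4-methoxyphenyl. The step from the pyridin-3-yl compound is only a bound, as compound 3 gives a limit: the limit of > 100000 nM in this assay, at which 1 of the 4 values shown sits.

Going by these compounds, how an unsubstituted phenyl, a 4-aminophenyl or a 4-carboxyphenyl would read at this position remains open. So does whether a methoxy group on the 1-benzothiophen-2-yl would lower the number as it did on the phenyl of compound 2.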